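The compounds below may be only part of what the source reports. "The series", "measured", "known", "first", "only" and "open" are said of these compounds alone.

Among the measured compounds shown here, in a functional assay on HCT-116 cells (Homo sapiens) for cytotoxicity (a lower number here means a stronger inhibitor, a higher number a weaker inhibitor), compound 2 `CCN(CC)CC1CCN(c2ccc(Nc3nc(NC4CCCCC4)c4nc[nH]c4n3)c(OC)c2)CC1` gives 74 nM, the higher of the two numbers so far, while compound 1 `COc1cc(N2CCC(CC(=O)N3CCOCC3)CC2)ccc1Nc1nc(NC2CCCCC2)c2nc[nH]c2n1` gives 36 nM. Compound 3 `COc1cc(N2CCC(CC(=O)N3CCC(N(C)C)C3)CC2)ccc1Nc1nc(NC2CCCCC2)c2nc[nH]c2n1` changes one group of compound 2: (3-(dimethylamino)pyrrolidin-1-yl)carbonyl in place of diethylamino on a saturated chain carbon bound to a saturated ring carbon. For the measured compounds named here, the one measured step that bears on this, a 2.1-fold higher number from compound 1 to compound 2 (0.31 log units; beyond the scatter), put diethylamino in place of (morpholin-4-yl)carbonyl. Going by these compounds, with a carbonyl group returning in compound 3, a modest step of similar size towards a lower number is expected, although this pyrrolidine group is untested. The expected change is a 2.1-fold lower number from compound 2 to compound 3 (0.33 log units; beyond the scatter). For compound 3 the estimated value is 35 nM, with an expected range from 12 nM to 105 nM.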

Compound 3, half-maximal inhibitory concentration: 59 nM
For compound 3 the middle estimate is 1.7-fold (0.23 log units) below the measured one; the range from low to high includes it.
By their numbers in this assay, from the lowest: compounds 1, 3 and 2 (each within the scatter of the next, the first and the last beyond it).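

In this assay there is a 1.3-fold lower number from compound 2 to compound 3 (0.10 log units; within the scatter) and a 1.6-fold higher number from compound 1 to compound 3 (0.21 log units; within the scatter), so compound 3 cannot be told apart from either of the other two, although those two differ from each other beyond the scatter. On this saturated chain carbon, the (3-(dimethylamino)pyrrolidin-1-yl)carbonyl group, with its ring and extra heavy atoms, therefore brings no clear loss. Nothing available explains this result. Still open, going by these compounds, is whether a piperazin-1-yl group on the carbonyl carbon, or a longer chain carrying the dimethylamino group, would shift the number beyond the scatter.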